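The source may report more compounds than this note shows. Statements on the series, on what has been measured and on what is new or still open speak of the compounds shown alone.

Compound 1, `COc1ccccc1Oc1ccc2c(NCCCNCc3ccco3)ccnc2c1`, was tested in a physicochemical assay for acid dissociation, and gives 9.28. Compound 2, `COc1ccc(Oc2ccc3c(NCCCNCc4cccc(OC)c4O)ccnc3c2)cc1`, gives 9.28, so compound 1 is level with compound 2 and the two stand together as the lowest of the three numbers measured. Within the data shown here, compound 3, `COc1cccc(CNCCCNc2ccnc3cc(Cc4ccc(F)cc4)ccc23)c1O`, gives 9.47, and the step of a number 0.19 log units higher from compound 2 to compound 3 (within the scatter); this was a 4-fluorobenzyl in place of 4-methoxyphenoxy on an aromatic carbon, the one measured step bearing on the present change. Compound 4, `FC(F)(F)c1ccc(-c2ccc3c(NCCCNCc4ccco4)ccnc3c2)cc1`, differs from compound 1 in that (4-(trifluoromethyl)phenyl in place of 2-methoxyphenoxy on an aromatic carbon). Both changes exchange one group on the same aromatic carbon of the shared core, far from the amine chain. Since the step from compound 2 to compound 3 stayed within the scatter, the step from compound 1 to compound 4 in this assay is expected to be a number 0.02 log units higher from compound 1 to compound 4 (within the scatter), no clear shift in either direction. Compound 4 is therefore estimated at 9.3, with a likely range from 8.9 to 9.7.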

Compound 4, acid dissociation constant: 9.47
The estimate for compound 4 lay 0.17 log units below the measured number; the measured number falls inside the stated range.
By their numbers in this assay, from the lowest: compounds 1, 2, 3 and 4 (each within the scatter of the next).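

In this assay, 4-(trifluoromethyl)phenyl in place of 2-methoxyphenoxy on this aromatic carbon gives a number 0.19 log units higher from compound 1 to compound 4 (within the scatter), so a group with three fluorine atoms and no hydrogen-bond acceptors can replace one with two acceptors without a clear shift. This is the second exchange at this carbon to stay within the scatter, here with a different group at the end of the amine chain. Nothing available explains this result. The groups shown at this carbon each carry one six-membered aromatic ring of carbon only. As far as these compounds go, whether a carboxylic acid or a primary amine there would also leave the number unshifted remains open.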